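From 3-(methoxymethoxy)phenyl to 4-(methoxymethoxy)phenyl: an expectation

The source may hold more compounds than are shown below. What is called first, only, known or untested is meant among the compounds shown, and "the series" means these compounds.

Values in a functional assay on MCF7 cells (Homo sapiens) for inhibition, read by MTT assay, with a stated time of 3 days (on this read-out higher numbers stand for weaker inhibition and lower numbers for stronger inhibition), so far
Compound 1 `COc1ccccc1/C=C/CCCOc1cc(/C=C\c2cc(OC)c(OC)c(OC)c2)ccc1OC` at 21000 nM
Compound 2 `COCOc1cccc(/C=C/CCCOc2cc(/C=C\c3cc(OC)c(OC)c(OC)c3)ccc2OC)c1` at 8000 nM

Of these two, compound 2 has the lower number and so shows the stronger inhibition. Compound 3 `COCOc1ccc(/C=C/CCCOc2cc(/C=C\c3cc(OC)c(OC)c(OC)c3)ccc2OC)cc1` has not been measured yet. It has the same atoms as compound 2, joined differently, with 4-(methoxymethoxy)phenyl in place of 3-(methoxymethoxy)phenyl on a double-bonded chain carbon bound to a double-bonded chain carbon. Within the data shown here, the only measured step at this place is a 2.6-fold lower number from compound 1 to compound 2 (0.42 log units; beyond the scatter) and it is modest. Among the measured compounds shown here, that step swapped one group for a different one, so no measured pair shows this move on its own. The expected step is no change at the digits printed from compound 2 to compound 3 (within the scatter) in this assay and nothing beyond the scatter is foreseen. For compound 3 the estimated value is 8000 nM within an expected range of 2500 nM to 25000 nM on the same read-out.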

Compound 3, half-maximal inhibitory concentration: 42000 nM
Beside the measured number, compound 3's estimate is 5.3-fold (0.72 log units) below it; the whole stated range lies below it.
By their numbers in this assay, from the lowest: compound 2; then compounds 1 and 3 (each within the scatter of the next).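

In this assay, 4-(methoxymethoxy)phenyl in place of 3-(methoxymethoxy)phenyl gives a 5.3-fold higher number from compound 2 to compound 3 (0.72 log units; beyond the scatter); the two compounds carry the same atoms, so this pair isolates where the methoxymethoxy group sits on the ring. The other new step, a 2.0-fold higher number from compound 1 to compound 3 (0.30 log units; within the scatter), lies within the scatter, so the methoxymethoxy group alone does not carry the advantage seen with compound 2: that advantage holds for 3-(methoxymethoxy)phenyl but not for 4-(methoxymethoxy)phenyl. No measured evidence here speaks to the reason for this difference.

Still open, as far as these compounds go, is whether the methoxymethoxy group itself matters, or whether a simple hydroxyl or methoxy in its place, as 3-hydroxyphenyl or 3-methoxyphenyl, would give a similar number. From the compounds shown here alone, how 2-(methoxymethoxy)phenyl or a phenyl ring bearing an amine or a carboxylic acid would behave also remains unknown.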